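The source may report more compounds than this note shows. Statements on the series, on what has been measured and on what is new or still open speak of the compounds shown alone.

Measured compounds: compound 1 `Nc1ccccc1NC(=O)c1ccc(CSC(=S)N2CCN(c3ccc(Cl)cc3)CC2)cc1` gives 15%; compound 2 `Nc1ccccc1NC(=O)c1ccc(CSC(=S)N2CCc3ccc([N+](=O)[O-])cc32)cc1` gives 30.6%; compound 3 `Nc1ccccc1NC(=O)c1ccc(CSC(=S)N2CCCC2)cc1` gives 27%.

All three numbers come from a functional assay on MGC-803 cells (Homo sapiens) for antiproliferative activity, read by CCK-8 assay, with a stated time of 72 h, tested at 2 uM; on this read-out higher numbers stand for a stronger effect at the one concentration tested and lower numbers for a weaker effect. Compound 1 stands lowest of the three: compound 3 lies above it beyond the scatter, and compound 2 lies further above it still. Compound 4 `Nc1ccccc1NC(=O)c1ccc(CSC(=S)N2CCN(Cc3cccnc3)CC2)cc1` differs from compound 1 in one place: (pyridin-3-yl)methyl in place of 4-chlorophenyl on an amine nitrogen in a ring. For the measured compounds named here, no measured pair isolates this change, so its size can only be expected from the spread the three numbers show. The step from compound 1 to compound 4 is expected to be small, a number 6 percentage points higher from compound 1 to compound 4 (within the scatter), an upward step that need not exceed the scatter. Compound 4 is therefore expected to give 21% in this assay, within a range from 8% to 36%.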

Compound 4, a percentage reported as inhibition, at one concentration (the size of the read-out at that concentration, not a potency): 37.7%
For compound 4 the middle estimate is 16.7 percentage points below the measured one, outside the stated range (above it).
By their numbers in this assay, from the lowest: compound 1; then compounds 3, 2 and 4 (each within the scatter of the next, the first and the last beyond it).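

In this assay, the amine nitrogen in the six-membered non-aromatic ring with 2 nitrogen proves to be a place where the group matters: (pyridin-3-yl)methyl in place of 4-chlorophenyl gives a number 22.7 percentage points higher from compound 1 to compound 4 (beyond the scatter). Both groups have 7 heavy atoms, though only the entering one has a hydrogen-bond acceptor. Nothing given accounts for the step.

The change alters both the ring and its attachment, and the two cannot be separated here. Benzyl, or pyridin-3-yl set directly on that nitrogen, would tell them apart.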